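The source may hold more compounds than are shown below. What is called first, only, known or untested is meant among the compounds shown, and "the series" means these compounds.

Measured compounds and their values:
compound 1, `O=C(/C(=C\c1ccc(O)c([N+](=O)[O-])c1)SCc1ccc(Cl)cc1)c1ccc(Cl)cc1`: 10000 nM
compound 2, `CN(C)c1ccc(/C=C(/SCc2ccc(F)cc2)C(=O)c2ccc(C(=O)O)cc2)cc1`: 10000 nM
compound 3, `CN(C)c1ccc(/C=C(/SCc2ccc(Cl)cc2)C(=O)c2ccc(Cl)cc2)cc1`: > 100000 nM

In a functional assay on DU-145 cells (Homo sapiens) for inhibition, read by trypan blue exclusion, with a stated time of 96 h (a higher number here means a weaker inhibitor of growth, a lower number a stronger inhibitor of growth), compound 1 gives 10000 nM. Compound 2 gives 10000 nM, level with compound 1 at the digits shown and within the usual scatter. For compound 3 the value is only a limit of the assay, (the limit of > 100000 nM in this assay, at which 1 of the 3 values shown sits). The change from compound 3 to compound 1 is 4-hydroxy-3-nitrophenyl in place of 4-(dimethylamino)phenyl on a double-bonded chain carbon bound to a double-bonded chain carbon, and it brought an at least 10-fold lower number from compound 3 to compound 1 (1.00 log units; beyond the scatter). Compound 4, `O=C(O)c1ccc(C(=O)/C(=C\c2ccc(O)c([N+](=O)[O-])c2)SCc2ccc(F)cc2)cc1`, carries the same change relative to compound 2: 4-hydroxy-3-nitrophenyl in place of 4-(dimethylamino)phenyl on a double-bonded chain carbon bound to a double-bonded chain carbon. The difference between the cores of compound 2 and compound 3 is not broken down here. Resting on the step measured from compound 3 to compound 1 an at least 10-fold lower number from compound 3 to compound 1 (1.00 log units; beyond the scatter), compound 4 is expected to show a 3.3-fold lower number from compound 2 to compound 4 (0.52 log units; beyond the scatter). Compound 4 is estimated at 3000 nM, between 500 nM and 20000 nM.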

Compound 4, concentration for 50% growth inhibition: > 100000 nM
Compound 4 was reported as a limit; the forecaster's own chance of this, stated with the estimate: 15%; middle value at least 33-fold (1.52 log units) away from the limit.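

In this assay, 4-hydroxy-3-nitrophenyl in place of 4-(dimethylamino)phenyl did not carry over from one core to the other, giving an at least 10-fold higher number from compound 2 to compound 4 (1.00 log units; beyond the scatter), opposite in direction to the earlier step: the same change on two cores in this assay, an at least 10-fold lower number (1.00 log units; beyond the scatter) from compound 3 to compound 1 and an at least 10-fold higher number (1.00 log units; beyond the scatter) from compound 2 to compound 4, at least 100-fold (2.00 log units) apart, beyond the scatter of two such steps. Both steps rest on a limit of the assay, so their sizes are bounds only: the limit of > 100000 nM in this assay, at which 2 of the 4 values shown sit. The result shows that, for these two pairs, the outcome of the change depends on the core, but it does not show which difference between the cores is responsible.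

As far as these compounds go, it remains open whether the opposite direction would persist with a methyl ester in place of the carboxylic acid of compound 2 and compound 4.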